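A few compounds are considered here, and "the series" means these few. Any claim that something is new, unique, unknown or untested is made for them only; others in the source may bear on it.

Measured so far in an ADME assay on 184B5 cells (Homo sapiens) for cytotoxicity, read by sulforhodamine B assay, with a stated time of 48 h; on this read-out higher numbers stand for weaker inhibition of growth and lower numbers for stronger inhibition of growth:

Compound 1 `O=C1C(=O)N(CN2CCN(c3ccnc4cc(C(F)(F)F)ccc34)CC2)c2cc(Br)ccc21` gives 21800 nM.
Compound 2 `O=C1C(=O)N(CN2CCN(c3ccnc4cc(C(F)(F)F)ccc34)CC2)c2ccccc21` gives 43900 nM.
Compound 3 `NC(=S)N/N=C1/C(=O)N(CN2CCN(c3ccnc4cc(C(F)(F)F)ccc34)CC2)c2cc(Br)ccc21` gives 21400 nM.

Compound 1 and compound 2 share one core and differ in a single place: hydrogen in place of bromo on an aromatic carbon. That change produced the step of a 2.0-fold higher number from compound 1 to compound 2 (0.30 log units; within the scatter), a shift that stays within the usual scatter of this kind of measurement. Compound 3 carries a different core; the difference between the two cores is not broken down here. The values of compound 3 and compound 1 lie within the scatter of each other, so nothing separates them.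

Compound 4 `NC(=S)N/N=C1/C(=O)N(CN2CCN(c3ccnc4cc(C(F)(F)F)ccc34)CC2)c2ccccc21` has not yet been measured. It relates to compound 3 exactly as compound 2 relates to compound 1: hydrogen in place of bromo on an aromatic carbon, at the same place on the same kind of ring. For the measured compounds named here, the only guide for the size of the step is the earlier one. The expected step is a 2.0-fold higher number from compound 3 to compound 4 (0.29 log units; within the scatter), resting on a 2.0-fold higher number from compound 1 to compound 2 (0.30 log units; within the scatter). In this assay compound 4 is therefore expected to give about 42000 nM, with a likely range from 20000 nM to 90000 nM.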

Compound 4, concentration for 50% growth inhibition: 20200 nM
Beside the measured number, compound 4's estimate is 2.1-fold (0.32 log units) above it; measured number inside the range.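

In this assay, putting hydrogen in place of bromo on the aromatic carbon gave a 1.1-fold lower number from compound 3 to compound 4 (0.03 log units; within the scatter) and so left the number within the usual scatter on this second core. Set beside the same change on the first core, the new step cannot be told apart from the earlier one: the same change on two cores in this assay, a 2.0-fold higher number (0.30 log units; within the scatter) from compound 1 to compound 2 and a 1.1-fold lower number (0.03 log units; within the scatter) from compound 3 to compound 4, 2.1-fold (0.33 log units) apart, within the scatter of two such steps. For the compounds shown here, nothing here speaks against carrying the change from one core to the other, but with only two small steps it does not show that the change has a real effect on either core, nor that it would behave alike on a third core.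

The compounds shown compare only bromo and hydrogen at this one place on the ring. From the compounds shown here alone, what a chloro group, a methoxy group or an amine would do at that place stays open, as does whether bromo on another carbon of the ring would give similar numbers.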